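The source may report more compounds than this note shows. Statements on the series, on what has been measured and on what is new or still open speak of the compounds shown alone.

Measured compounds:
- Compound 1 `O=C1N=C(N2N=C(c3ccccc3)CC2c2ccccc2O)S/C1=C1/C(=O)Nc2ccccc21`: 2090 nM
- Compound 2 `O=C1N=C(N2N=C(c3ccccc3)CC2c2ccccc2O)S/C1=C1/C(=O)Nc2ccc(Br)cc21`: 260 nM
- Compound 3 `COc1ccc(C2CC(c3ccc4ccccc4c3)=NN2C2=NC(=O)/C(=C3\C(=O)Nc4ccccc43)S2)cc1`: 5960 nM

All three were tested in a functional assay on cells (Cancer cell lines, Homo sapiens) for cytotoxicity, read by sulforhodamine B assay, with a stated time of 48 h; a higher number here means a weaker inhibitor of growth, a lower number a stronger inhibitor of growth. Compound 2 gives the lowest number of the three, and its distance to compound 1 and to compound 3 is beyond the scatter in each case, so it stands as the most potent of the measured set. Within the data shown here, the one step that can be read in isolation is an 8.0-fold lower number from compound 1 to compound 2 (0.91 log units; beyond the scatter), a change on the aromatic ring of the shared core; it does not touch the part of the molecule that changes next.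

Compound 4 `CN(C)c1ccc(C2CC(c3ccccc3)=NN2C2=NC(=O)/C(=C3\C(=O)Nc4ccc(Br)cc43)S2)cc1` keeps the bromo of compound 2 and differs from it only in the group on the saturated ring carbon: 4-(dimethylamino)phenyl in place of 2-hydroxyphenyl on a saturated ring carbon. Compound 3 carries a different aryl group at that same position but also a naphthyl group and no bromo, so its number cannot be separated into single steps. Among the measured compounds shown here, no measured step bears directly on this change, and the expectation is a step within the scatter, a 1.7-fold higher number from compound 2 to compound 4 (0.24 log units; within the scatter), in either direction. Compound 4 is therefore expected to give about 450 nM, with a range from 130 nM to 1600 nM.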

Compound 4, concentration for 50% growth inhibition: 220 nM
Estimate against measurement, compound 4: 2.0-fold (0.31 log units) above, within the range that was stated.
By their numbers in this assay, from the lowest: compounds 4 and 2 (each within the scatter of the next); then compound 1; then compound 3.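

In this assay, among these compounds, putting 4-(dimethylamino)phenyl in place of 2-hydroxyphenyl on the saturated ring carbon gives a 1.2-fold lower number from compound 2 to compound 4 (0.07 log units; within the scatter), so with the bromo kept, this is the first single change at this position, and it makes no difference that can be told from scatter. The hydrogen-bond donor of the 2-hydroxyphenyl group is absent from 4-(dimethylamino)phenyl, so in this one pair that donor is not needed to keep the number at this level. Nothing measured here explains why the two groups give matching numbers.

Still open, on these data alone, is whether a carboxylic acid on this phenyl ring, or a plain methyl in place of the whole aryl group, would hold the number at this level. As far as these compounds go, it is also open whether the same exchange would behave alike on the core of compound 1, which has no bromo.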